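A few compounds are considered here, and "the series" means these few. Any claim that something is new, unique, unknown or untested is made for them only; others in the source may bear on it.

Compound 1, with the structure `O=C1CC(c2ccccc2O)Oc2ccccc21`, carries a free hydroxyl on its side ring. In a functional assay on RAW264.7 cells (Mus musculus) for inhibition, read by Griess assay, with stated times of 1 h and 24 h (a higher number here means a weaker inhibitor, a lower number a stronger inhibitor), compound 1 gives 71300 nM. Compound 2, with the structure `CC(C)COc1ccccc1C1CC(=O)c2ccccc2O1`, is the same molecule with the hydroxyl hydrogen exchanged for isobutyl; in this assay compound 2 gives 36700 nM. Going by the values given here, that single exchange produced a 1.9-fold lower number from compound 1 to compound 2 (0.29 log units; within the scatter), so among the two numbers measured so far compound 2 stands lowest, with compound 1 as its only neighbour, and the two cannot be told apart with confidence.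

Compound 3, with the structure `COc1ccccc1C1CC(=O)c2ccccc2O1`, has not yet been measured. It differs from compound 2 in one place: hydrogen in place of isopropyl on a saturated chain carbon bound to an oxygen on an aromatic ring. Among the compounds with values here, the only measured step that bears on this is the one from compound 1 to compound 2, where adding the whole isobutyl group to that oxygen gave a change within the scatter. Shortening the group to methyl is a smaller move than the one already seen, so for compound 3 the expected step in this assay is a 1.4-fold higher number from compound 2 to compound 3 (0.13 log units; within the scatter), with no clear direction. The estimate for compound 3 is 50000 nM, within 20000 nM to 120000 nM.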

Compound 3, half-maximal inhibitory concentration: 47300 nM
For compound 3 the middle estimate is 1.1-fold (0.02 log units) above the measured one; the range from low to high includes it.
By their numbers in this assay, from the lowest: compounds 2, 3 and 1 (each within the scatter of the next).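

The earlier pair had only hydrogen and isobutyl on this oxygen, and methyl now adds a point of intermediate chain length. In this assay the two new steps are a 1.3-fold higher number from compound 2 to compound 3 (0.11 log units; within the scatter) and a 1.5-fold lower number from compound 1 to compound 3 (0.18 log units; within the scatter), so neither the move from isobutyl to methyl nor the move from hydrogen to methyl can be told apart from repeat-measurement noise. Across these three compounds, then, the read-out does not separate a free hydroxyl, methoxy and isobutoxy, and no other data accompany the numbers to explain this result.

As far as these compounds go, what remains open is whether a chain longer than isobutyl, or a group of a different kind on this oxygen, such as a chain ending in an amine or a carboxylic acid, would shift the number beyond the scatter. All three compounds also share one core, so whether the same exchanges would read the same way on a different core remains unanswered.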